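Working notes: the nitrogen substituent of compound 1 removed

This account rests on a few compounds, and the source may have more. Where it says the series, first, only, none or still open, it means among the compounds named here.

Compound 1 `CCOC(=O)C1=C(NN=C(C(C)=O)C(C)=O)Nc2[nH]nc(C)c2C1c1ccc(N(C)C)cc1` is the reference point of this small set. In a functional assay on HepG2 cells (Homo sapiens) for inhibition, read by MTT assay, with a stated time of 48 h (a higher number here means a weaker inhibitor, a lower number a stronger inhibitor), compound 1 gives 8480 nM, the lowest of the three numbers recorded. Compound 2 `CCOC(=O)C1=C(N/N=C(/C#N)C(=O)OCC)Nc2[nH]nc(C)c2C1c1ccc(N(C)C)cc1` gives 46400 nM and compound 3 `CCOC(=O)C1=C(N/N=C(/Br)c2ccccc2)Nc2[nH]nc(C)c2C1c1ccc(N(C)C)cc1` gives 72000 nM. The measured steps are a 5.5-fold higher number from compound 1 to compound 2 (0.74 log units; beyond the scatter) and an 8.5-fold higher number from compound 1 to compound 3 (0.93 log units; beyond the scatter), while between the two weaker members the step is a 1.6-fold higher number from compound 2 to compound 3 (0.19 log units; within the scatter).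

Compound 4 `CCOC(=O)C1=C(N)Nc2[nH]nc(C)c2C1c1ccc(N(C)C)cc1` has not yet been measured. It differs from compound 1 at the same site that both measured steps alter: a hydrogen atom in place of a group of 8 heavy atoms (5 carbon, 1 nitrogen, 2 oxygen; no ring), on an amine nitrogen. The steps from compound 1 to compound 2 and from compound 1 to compound 3 bear on it, since each exchanges the same group on the amine nitrogen for another group and each gives a higher number beyond the scatter. Among the measured compounds shown here, no measured compound carries only a hydrogen at this position, so the direction is taken from those two exchanges and the size is uncertain. For compound 4 the expected step is a 3.5-fold higher number from compound 1 to compound 4 (0.55 log units; beyond the scatter), a higher number. The estimate for compound 4 is 30000 nM, with a range from 8000 nM to 120000 nM.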

Compound 4, half-maximal inhibitory concentration: 4240 nM
The estimate for compound 4 lay 7.1-fold (0.85 log units) above the measured number; the whole stated range lies above it.
By their numbers in this assay, from the lowest: compounds 4 and 1 (each within the scatter of the next); then compounds 2 and 3 (each within the scatter of the next).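

In this assay the exchange of the whole group for a hydrogen atom gives a 2.0-fold lower number from compound 1 to compound 4 (0.30 log units; within the scatter) and so leaves the two compounds within the scatter of each other: on this amine nitrogen, the group of compound 1 is not required for the number it gives. Set against the other two groups, the same hydrogen atom gives a 17-fold lower number from compound 3 to compound 4 (1.23 log units; beyond the scatter) and an 11-fold lower number from compound 2 to compound 4 (1.04 log units; beyond the scatter) so the higher numbers at this position go with those two substituents and not with the loss of a group. Nothing available explains these differences.

The compounds shown leave open where a methyl or acetyl group, or a longer alkyl chain, on this amine nitrogen would fall. They also leave open whether a simple amide here would stay with compounds 1 and 4 or join compounds 2 and 3.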